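This account rests on a few compounds, and the source may have more. Where it says the series, first, only, none or still open, it means among the compounds named here.

Measured compounds and their values:
- compound 1, `COC(=O)/C(=C/c1ccccc1)CN1C(=O)[C@@H](OC)[C@H]1c1ccc(Cl)cc1`: 37900 nM
- compound 2, `COC(=O)/C(=C/c1ccccc1)CN1C(=O)[C@@H](OC)[C@H]1c1ccccc1C(F)(F)F`: "not toxic" (no number reported)
- compound 3, `COC(=O)/C(=C/c1ccccc1)CN1C(=O)[C@@H](OC)[C@H]1c1cccc(Cl)c1`: "not toxic" (no number reported)

All three compounds share one core and differ only in the aromatic group attached to the four-membered ring. In an ADME assay on cells (Epithelial cell, Homo sapiens) for antiproliferative activity, read by MTT assay, with a stated time of 48 h (on this read-out higher numbers stand for weaker inhibition and lower numbers for stronger inhibition), compound 1 gives 37900 nM, a weak effect. Compound 2 gives "not toxic" (no number reported) in this assay, so no number stands behind it. Compound 3 likewise gives "not toxic" (no number reported) in this assay; it is one of two compounds here for which no single number is reported, and it therefore cannot be placed above or below compound 1 on the scale.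

Among the compounds with values here, the step to compound 4, `COC(=O)/C(=C/c1ccccc1)CN1C(=O)[C@@H](OC)[C@H]1c1ccc(OC)cc1`, changes only that aromatic group: 4-methoxyphenyl in place of 3-chlorophenyl on a saturated ring carbon. Within the data shown here, no measured pair in this set shows what such a change does, so the size of the step in this assay is not known from data, and nothing here points to a shift in either direction beyond the usual scatter.

On the weak or absent effects of compound 1, compound 2 and compound 3, compound 4 is expected to show at most a weak effect, estimated at 60000 nM with a likely range from 20000 nM to 200000 nM, and a real chance that again no number is obtained.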

Compound 4, half-maximal inhibitory concentration: "not toxic" (no number reported)
For compound 4 the study gives words and no number; the estimate stays without a comparison.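

In this assay, within the data shown here, compound 3 and compound 4 both come without a number, so no step from 3-chlorophenyl to 4-methoxyphenyl can be read. No measurement shown here offers a reason for this result. The compounds shown leave open how much the aromatic group changes the effect: only compound 1 has a number (37900 nM).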